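Cytotoxicity of Three Measured Compounds and One Analogue

A few compounds are considered here, and "the series" means these few. Any claim that something is new, unique, unknown or untested is made for them only; others in the source may bear on it.

Compound 1 `CCCC(=O)OCSc1ccccc1C(=O)NCCCCC(N)=O`: 51.7 uM
Compound 2 `CCCC(=O)OCSc1ccccc1C(=O)N(C)CC(N)=O`: 55.3 uM
Compound 3 `CCCC(=O)OCSc1ccccc1C(=O)N(C)CC(=O)NC`: 62.5 uM

In an ADME assay on CEM-SS cells (Homo sapiens) for cytotoxicity, read by XTT assay, with a stated time of 6 days (on this read-out higher numbers stand for lower toxicity in this test and lower numbers for higher toxicity in this test), compound 1 gives 51.7 uM, the lowest of the three numbers, although the step of a 1.1-fold higher number from compound 1 to compound 2 (0.03 log units; within the scatter) and the step of a 1.2-fold higher number from compound 1 to compound 3 (0.08 log units; within the scatter) both stay within the scatter, so the three compounds are indistinguishable here. Compound 4 `CCCCCNC(=O)CNC(=O)c1ccccc1SCOC(=O)CCC` differs from compound 1 by pentylcarbamoyl in place of 3-carbamoylpropyl on a saturated chain carbon bound to an amide-type nitrogen. Among the measured compounds shown here, none of the measured steps makes this change; the steps that exist, a 1.1-fold higher number from compound 1 to compound 2 (0.03 log units; within the scatter), a 1.2-fold higher number from compound 1 to compound 3 (0.08 log units; within the scatter) and a 1.1-fold higher number from compound 2 to compound 3 (0.05 log units; within the scatter), alter the same amide-bearing chain in other ways and all remain within the scatter. On that basis compound 4 is expected to show no step beyond the scatter, a 1.0-fold lower number from compound 1 to compound 4 (0.01 log units; within the scatter). Compound 4 is therefore estimated at 50 uM, with a range from 28 uM to 90 uM.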

Compound 4, half-maximal toxic concentration: 24.8 uM
For compound 4 the middle estimate is 2.0-fold (0.30 log units) above the measured one, and the stated range ends above it.
By their numbers in this assay, from the lowest: compound 4; then compounds 1, 2 and 3 (each within the scatter of the next).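

In this assay, among the compounds shown here, the change to pentylcarbamoyl in place of 3-carbamoylpropyl, on a saturated chain carbon bound to an amide-type nitrogen, gives the first step beyond the scatter (a 2.1-fold lower number from compound 1 to compound 4 (0.32 log units; beyond the scatter)), a modest move towards higher toxicity in this test. The earlier changes to this amide-bearing chain all stayed within the scatter, so the chain does not tolerate every change equally. Nothing measured here explains the step.

Going by these compounds, whether a longer chain such as hexylcarbamoyl would go further in the same direction remains open. So does the effect of a carboxylic acid or an amine in this place.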